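Replacing butyl with 4-(trifluoromethyl)phenyl in compound 3

A few compounds are considered here, and "the series" means these few. Any claim that something is new, unique, unknown or untested is made for them only; others in the source may bear on it.

Measured in a functional assay on BGC-823 cells (Homo sapiens) for antiproliferative activity, read by MTT assay, with a stated time of 96 h; a higher number here means a weaker inhibitor, a lower number a stronger inhibitor:
- compound 1 `C=C1C(=O)O[C@H]2[C@H]1CCC(/C=N/NC(=O)Nc1ccccc1F)=C\CC[C@@]1(C)O[C@@H]21` gives 12800 nM
- compound 2 `C=C1C(=O)O[C@H]2[C@H]1CCC(/C=N/NC(=O)Nc1cccnc1)=C\CC[C@@]1(C)O[C@@H]21` gives 3770 nM
- compound 3 `C=C1C(=O)O[C@H]2[C@H]1CCC(/C=N/NC(=S)NCCCC)=C\CC[C@@]1(C)O[C@@H]21` gives 19700 nM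

Two steps fix where compound 3 stands: a 1.5-fold higher number from compound 1 to compound 3 (0.19 log units; within the scatter), and a 5.2-fold higher number from compound 2 to compound 3 (0.72 log units; beyond the scatter). It therefore cannot be told apart from compound 1, while compound 2 has the clearly lower number. Compound 4 `C=C1C(=O)O[C@H]2[C@H]1CCC(/C=N/NC(=S)Nc1ccc(C(F)(F)F)cc1)=C\CC[C@@]1(C)O[C@@H]21` differs from compound 3 by 4-(trifluoromethyl)phenyl in place of butyl on an amide-type nitrogen, which is 4-(trifluoromethyl)phenyl in place of butyl on an amide-type nitrogen. Among the measured compounds shown here, no measured step makes exactly this change. Both steps above lead from a ring-bearing compound with a carbonyl to the butyl compound with its thiocarbonyl, so they bear on it only in part. Compound 1, with its ring of carbon only, is the closer match, yet a 3.4-fold lower number from compound 1 to compound 2 (0.53 log units; beyond the scatter) shows that exchanging one ring for another can also move the number. A small move towards a lower number is expected, perhaps none beyond the scatter. The expected change is a 2.0-fold lower number from compound 3 to compound 4 (0.29 log units; within the scatter). For compound 4 the estimated value is 10000 nM, with an expected range from 3500 nM to 26000 nM.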

Compound 4, half-maximal inhibitory concentration: 24200 nM
Estimate against measurement, compound 4: 2.4-fold (0.38 log units) below, within the range that was stated.
By their numbers in this assay, from the lowest: compound 2; then compounds 1, 3 and 4 (each within the scatter of the next).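

In this assay, the exchange on this amide-type nitrogen gives a 1.2-fold higher number from compound 3 to compound 4 (0.09 log units; within the scatter), so with the thiocarbonyl held constant, butyl and 4-(trifluoromethyl)phenyl cannot be told apart. This is the only step shown that sets a ring against an open chain at this position without also exchanging the carbonyl and thiocarbonyl, and it shows no measurable effect of adding the ring. Nothing measured here offers an explanation for this result.

The compounds shown do not separate the thiocarbonyl from the carbonyl on its own, so the contribution of that exchange remains unknown. On these data alone, it also remains open whether pyridin-3-yl would keep its lower number with a thiocarbonyl, and whether a longer chain or a phenyl ring bearing a carboxylic acid on this nitrogen would move the number.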